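This account rests on a few compounds, and the source may have more. Where it says the series, first, only, none or still open, it means among the compounds named here.

Measured so far in a functional assay on MONO-MAC-6 cells (Homo sapiens) for inhibition; on this read-out higher numbers stand for weaker inhibition and lower numbers for stronger inhibition:
compound 2 `O=C(NO)[C@H]1CCCCN1S(=O)(=O)N1CC=C(c2ccc(F)cc2)CC1` — 300 nM
compound 1 `C[C@@H](NS(=O)(=O)N1CC=C(c2ccc(Cl)cc2)CC1)C(=O)NO` — 1240 nM
compound 3 `O=C(NO)[C@H]1CCCCN1S(=O)(=O)N1CC=C(c2ccc(-c3ccccc3)cc2)CC1` — 19000 nM

Compound 2 stands lowest of the three numbers in this assay; compound 1 is the nearest, compound 3 the furthest. Compound 4 `CCc1cccc(C2=CCN(S(=O)(=O)N3CCCC[C@@H]3C(=O)NO)CC2)c1` differs from compound 2 by 3-ethylphenyl in place of 4-fluorophenyl on a double-bonded ring carbon. Among the measured compounds shown here, the one measured step at this place is a 63-fold higher number from compound 2 to compound 3 (1.80 log units; beyond the scatter); it is the only guide, and it replaced the same fluoro with a group of carbon only, as compound 4 does. For the measured compounds named here, a weaker inhibition is therefore expected for compound 4, though not as far as in that step, since no measured compound carries the 3-ethylphenyl itself. The expected step is a 4.0-fold higher number from compound 2 to compound 4 (0.60 log units; beyond the scatter). Compound 4 is estimated at 1200 nM, with a range of 300 nM to 6000 nM.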

Compound 4, half-maximal inhibitory concentration: 320 nM
Compound 4: middle estimate off by 3.8-fold (0.57 log units), on the high side; measured number inside the range.
By their numbers in this assay, from the lowest: compounds 2 and 4 (each within the scatter of the next); then compound 1; then compound 3.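

In this assay, swapping in 3-ethylphenyl on the double-bonded ring carbon gives a 1.1-fold higher number from compound 2 to compound 4 (0.03 log units; within the scatter). A carbon-only aryl group at this position therefore does not by itself bring a loss of the size of a 63-fold higher number from compound 2 to compound 3 (1.80 log units; beyond the scatter), which remains tied in this series to the phenyl that replaced fluoro on the aromatic carbon. No evidence at hand accounts for the difference between these two steps. Still open, as far as these compounds go, is whether a methoxy group or a longer chain such as propyl in place of the ethyl would stay within the scatter of compound 2.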